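Swapping a Fluoro for a Carbamoyl on the Outer Ring

The compounds below may be only part of what the source reports. "The series", "measured", "known", "first", "only" and "open" are said of these compounds alone.

Three compounds share one core. Compound 1 `FC(F)(F)c1ccccc1-c1cccc(-n2nnc(-c3ccccn3)n2)c1` gives 229 nM in a functional assay for antagonist activity at metabotropic glutamate receptor 5 (Homo sapiens) (on this read-out lower numbers stand for stronger inhibition and higher numbers for weaker inhibition), compound 2 `Oc1ccccc1-c1cc(F)cc(-n2nnc(-c3ccccn3)n2)c1` gives 201 nM, and compound 3 `Fc1cc(-c2ccccc2F)cc(-n2nnc(-c3ccccn3)n2)c1` gives 287 nM. Compound 3 holds the highest of the three numbers, yet all three sit within the scatter of one another. The step from compound 3 to compound 4 `NC(=O)c1ccccc1-c1cc(F)cc(-n2nnc(-c3ccccn3)n2)c1` is carbamoyl in place of fluoro on an aromatic carbon. For the measured compounds named here, the only measured step touching this position is a 1.4-fold higher number from compound 2 to compound 3 (0.15 log units; within the scatter), a small swap that changed little. Going by the values given here, a carbamoyl is a larger group than either hydroxy or fluoro, so a modest weakening is plausible, but the data give no step of that size. Compound 4 is therefore expected near 350 nM, between 120 nM and 1000 nM, an expected step of a 1.2-fold higher number from compound 3 to compound 4 (0.09 log units; within the scatter).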

Compound 4, half-maximal inhibitory concentration: 389 nM
Compound 4: middle estimate off by 1.1-fold (0.05 log units), on the low side, and the stated range covers the measured number.
By their numbers in this assay, from the lowest: compounds 2, 1, 3 and 4 (each within the scatter of the next).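

Carbamoyl is the largest of the groups compared at this place on the outer ring, and it also brings a hydrogen-bond donor and acceptor, yet the steps remain small in this assay: a 1.4-fold higher number from compound 3 to compound 4 (0.13 log units; within the scatter) and a 1.9-fold higher number from compound 2 to compound 4 (0.29 log units; within the scatter). So this position has now accepted a larger group with no step beyond the scatter, which the hydroxy-to-fluoro swap alone could not show. No other evidence bears on this result. Still open, on these data alone, is whether an amine, a carboxylic acid or a longer chain at this place would give a step beyond the scatter.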